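This account rests on a few compounds, and the source may have more. Where it says the series, first, only, none or still open, it means among the compounds named here.

Compound 1 `O=C(Nc1ccc(Cl)cc1)Nc1ccc(Nc2ncnc3c2OCCN3)cc1` gives 2280 nM in an assay on isolated protein for inhibition of proto-oncogene tyrosine-protein kinase receptor Ret variant V804M (Homo sapiens), read by 33P incorporation, with stated times of 15 min and 40 min; on this read-out lower numbers stand for stronger inhibition and higher numbers for weaker inhibition. Compound 2 `COc1ccc(NC(=O)Nc2ccc(Nc3ncnc4c3OCCN4)cc2)cc1` gives 824 nM. Compound 3 `O=C(Nc1ccc(Nc2ncnc3c2OCCN3)cc1)Nc1cccc2ccccc12` reaches only a limit of the assay, > 10000 nM.

Among the numbers shown, compound 1 stands highest of the two: the other number lies lower, a 2.8-fold lower number from compound 1 to compound 2 (0.44 log units; beyond the scatter), after methoxy in place of chloro on an aromatic carbon. Compound 3 sits at the limit (the limit of > 10000 nM in this assay, at which 1 of the 3 values shown sits), and the step to it is an at least 4.3-fold higher number from compound 1 to compound 3 (0.64 log units; beyond the scatter), after naphthalen-1-yl in place of 4-chlorophenyl on an amide-type nitrogen.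

Compound 4 `O=C(Nc1ccc(Nc2ncnc3c2OCCN3)cc1)Nc1cccs1` differs from compound 1 in one place: thiophen-2-yl in place of 4-chlorophenyl on an amide-type nitrogen. For the measured compounds named here, the step that bears on this most closely is the one to compound 3, where the same group on the amide-type nitrogen was swapped for a larger two-ring system and the number rose well beyond the scatter. The step to compound 2 shows that a small change on that ring moves the number only modestly. Going by the values given here, no measured step swaps in a smaller ring, so the direction is uncertain; a change of no more than a modest size, in either direction, is expected in this assay.

Compound 4 is therefore estimated at 2500 nM, within 800 nM to 8000 nM. This estimate means an expected step of a 1.1-fold higher number from compound 1 to compound 4 (0.04 log units; within the scatter).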

Compound 4, half-maximal inhibitory concentration: 8640 nM
Estimate against measurement, compound 4: 3.5-fold (0.54 log units) below, outside the stated range (above it).
By their numbers in this assay, from the lowest: compound 2; then compound 1; then compound 4. At a limit, above all of these: compound 3.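

In this assay, thiophen-2-yl in place of the 4-chlorophenyl on this amide-type nitrogen gives a modest rise in the number, toward weaker inhibition: a 3.8-fold higher number from compound 1 to compound 4 (0.58 log units; beyond the scatter). So far, a rise had appeared only with the larger, two-ring naphthalen-1-yl, so the new result shows that a smaller ring in this place can also weaken inhibition. Measured from the 4-methoxyphenyl group, the same ring gives a large step, a 10-fold higher number from compound 2 to compound 4 (1.02 log units; beyond the scatter). Compound 3 sits at a limit, so all that can be given for that step is a floor, an at least 1.1-fold lower number from compound 3 to compound 4 (0.06 log units; that floor lies within the scatter), and no order can be drawn from it: the limit of > 10000 nM in this assay, at which 1 of the 4 values shown sits.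

The compounds shown do not separate the effect of changing the ring itself from that of losing the chloro or methoxy group it carried, since thiophen-2-yl differs from both phenyl groups in these two ways at once. A plain phenyl group, or a thiophen-2-yl ring carrying a chloro or methoxy group, would address that question, and a pyridinyl ring would test another six-membered ring in this place.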